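A few compounds are considered here, and "the series" means these few. Any claim that something is new, unique, unknown or untested is made for them only; others in the source may bear on it.

Among the compounds with values here, in an assay on a protein complex for inhibition of CDK8/Cyclin C (Homo sapiens), with a stated time of 1 h (a lower number here means a stronger inhibitor, a higher number a weaker inhibitor), compound 2 `COC(=O)/C=C/c1ccncc1-c1ccc2ccccc2c1` gives 40.6 nM, and that is the only number in hand; compound 1 `NNC(=O)COc1ccncc1-c1ccc2ccccc2c1` was examined but its entry in this assay reads "not determined" (no result reported), so compound 2 stands alone without any neighbour to compare against. Compound 3 `O=C(O)CCc1ccncc1-c1ccc2ccccc2c1` differs from compound 2 by a single change: 2-carboxyethyl in place of 2-(methoxycarbonyl)ethenyl on an aromatic carbon. Within the data shown here, no measured pair shows what such a change does here, so the expectation rests on compound 2 alone. A modest loss beyond the usual scatter is expected, a 3.7-fold higher number from compound 2 to compound 3 (0.57 log units; beyond the scatter). Compound 3 is therefore estimated at 150 nM, with a plausible range from 30 nM to 800 nM.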

Compound 3, half-maximal inhibitory concentration: 50.5 nM
The estimate for compound 3 lay 3.0-fold (0.47 log units) above the measured number, within the range that was stated.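

In this assay, putting 2-carboxyethyl in place of 2-(methoxycarbonyl)ethenyl on this aromatic carbon gives a 1.2-fold higher number from compound 2 to compound 3 (0.09 log units; within the scatter) and so leaves the two compounds indistinguishable. This position therefore carries either chain with no readable change, even though the entering group has one hydrogen-bond donor where the leaving group has none. No measurement at hand offers an explanation for this. Still open, on these data alone, is how an amine or a longer chain would read here, and whether a saturated methyl ester or an unsaturated carboxylic acid would read the same, which would separate the parts of this change.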